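One Measured Value and a Swap on an Aromatic Nitrogen

The source may report more compounds than this note shows. Statements on the series, on what has been measured and on what is new or still open speak of the compounds shown alone.

In a functional assay on MCF7 cells (Homo sapiens) for antiproliferative activity, read by MTT assay (on this read-out lower numbers stand for stronger inhibition and higher numbers for weaker inhibition), three related compounds have been tested so far. Compound 1 `CC1(C)CCc2cc(C(=O)/C=C/c3ccc(OCc4cn(-c5ccc(Cl)cc5)nn4)cc3)c(O)cc2O1` is recorded as "not active" (no number reported) and compound 2 `CC1(C)CCc2cc(C(=O)/C=C/c3ccc(OCc4cn(-c5ccc(Br)cc5)nn4)cc3)c(O)cc2O1` as "not active" (no number reported) with no number given. Among the measured compounds shown here, compound 3 `CC(=O)c1ccc(-n2cc(COc3ccc(/C=C/C(=O)c4cc5c(cc4O)OC(C)(C)CC5)cc3)nn2)cc1` gives 182000 nM and is the only compound with a number, so there is no numerical ranking to place it in.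

Compound 4 `CCc1ccccc1-n1cc(COc2ccc(/C=C/C(=O)c3cc4c(cc3O)OC(C)(C)CC4)cc2)nn1` has yet to be measured. The change from its neighbour is 2-ethylphenyl in place of 4-acetylphenyl on an aromatic nitrogen and, in short, it puts 2-ethylphenyl in place of 4-acetylphenyl on an aromatic nitrogen. For the measured compounds named here, no measured pair of compounds shows what a swap of this kind does, so the data favour no direction. The expected 1.1-fold higher number from compound 3 to compound 4 (0.04 log units; within the scatter) is small, none beyond the usual scatter. Compound 1 and compound 2 returned no number, so the same outcome is a real possibility for compound 4. If a number does appear, the estimate for compound 4 is 200000 nM with an expected range from 70000 nM to 500000 nM around that figure.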

Compound 4, half-maximal inhibitory concentration: "not active" (no number reported)
The entry for compound 4 holds no number; there is nothing to compare the estimate with.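

Among the compounds shown here, compound 3 gives 182000 nM and compound 4 is recorded without a number, so no step between compound 3 and compound 4 can be read. Nothing measured here offers an explanation for this result. The compounds shown leave open what a swap on the aromatic nitrogen does to the number in this assay.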